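Amide-region change on the shared core: compound 3 to compound 4

A few compounds are considered here, and "the series" means these few. Any claim that something is new, unique, unknown or untested is made for them only; others in the source may bear on it.

Compound 1 `O=C(c1cccc(Nc2ncc(F)c(Nc3ccc(F)cc3)n2)c1)N1CCCCC1` gives 13000 nM in a functional assay on DU-145 cells (Homo sapiens) for antiproliferative activity, read by sulforhodamine B assay, with a stated time of 3 days; a higher number here means a weaker inhibitor of growth, a lower number a stronger inhibitor of growth. Compound 2 `O=C(NCCO)c1cccc(Nc2ncc(F)c(Nc3ccc(F)cc3)n2)c1` gives 13400 nM, and compound 3 `Cn1ccnc1NC(=O)c1cccc(Nc2ncc(F)c(Nc3ccc(F)cc3)n2)c1` gives 15100 nM. Compound 3 holds the highest of the three numbers, yet the steps of a 1.2-fold higher number from compound 1 to compound 3 (0.07 log units; within the scatter) and a 1.1-fold higher number from compound 2 to compound 3 (0.05 log units; within the scatter) are within the scatter, as is a 1.0-fold higher number from compound 1 to compound 2 (0.01 log units; within the scatter), so the three compounds cannot be told apart here. Compound 4 `CN(C)CC(=O)Nc1cccc(Nc2ncc(F)c(Nc3ccc(F)cc3)n2)c1` differs from compound 3 by (((dimethylamino)methyl)carbonyl)amino in place of (1-methyl-1H-imidazol-2-yl)carbamoyl on an aromatic carbon. Within the data shown here, none of the measured steps changes this same part; the steps at the carbonyl carbon and at the amide-type nitrogen, all flat, are the nearest guide. The step is expected to be a 1.1-fold lower number from compound 3 to compound 4 (0.03 log units; within the scatter), nothing beyond the scatter, with wide uncertainty. Compound 4 is therefore estimated at 14000 nM, with a range from 5000 nM to 40000 nM.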

Compound 4, concentration for 50% growth inhibition: 1210 nM
For compound 4 the middle estimate is 12-fold (1.06 log units) above the measured one; the measured number lies below the stated range.
By their numbers in this assay, from the lowest: compound 4; then compounds 1, 2 and 3 (each within the scatter of the next).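

This position on the aromatic carbon responds in this assay where the carbonyl-side changes stayed flat: (((dimethylamino)methyl)carbonyl)amino stands apart from all three carbonyl-linked amides (a 12-fold lower number from compound 3 to compound 4 (1.10 log units; beyond the scatter); an 11-fold lower number from compound 2 to compound 4 (1.04 log units; beyond the scatter); an 11-fold lower number from compound 1 to compound 4 (1.03 log units; beyond the scatter)). Those three remain within the scatter of each other, so the large step holds whichever amide it starts from. No measured evidence bears on this result.

Open, as far as these compounds go, is whether the amide nitrogen on the aromatic carbon or the dimethylamino group carries the step, since both change together. A plain acetylamino group, or a piperidin-1-yl or longer chain in place of dimethylamino, would separate the two.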